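A few compounds are considered here, and "the series" means these few. Any claim that something is new, unique, unknown or untested is made for them only; others in the source may bear on it.

Two compounds of the series have been run in a functional assay on NCI-H2122 cells (Homo sapiens) for inhibition, read by microscopy, with a stated time of 10 days; a lower number here means a stronger inhibitor, a higher number a weaker inhibitor. Compound 1 `N#CC1=C(N)Oc2c(c(-c3ccccc3)nn2-c2ccccc2)C1c1ccc(F)cc1` gives 4100 nM. Within the data shown here, compound 2 `COc1ccc(C2C(C#N)=C(N)Oc3c2c(-c2ccccc2)nn3C)cc1`, which carries a methyl on the aromatic nitrogen, reaches only a limit in this assay, > 10000 nM, so no number is fixed for it; it sits at the weak end of what this assay reports, the one value that rests on (the limit of > 10000 nM in this assay, at which 1 of the 2 values shown sits). Compound 3 `COc1ccc(C2C(C#N)=C(N)Oc3c2c(-c2ccccc2)nn3-c2ccccc2)cc1` differs from compound 2 by phenyl in place of methyl on an aromatic nitrogen. Among the measured compounds shown here, no measured pair of the series isolates this change, so its size is not known from the data. Compound 1 carries the same phenyl on that nitrogen and stands at 4100 nM, which points toward a gain rather than no change or a loss. The step from compound 2 to compound 3 is therefore expected at an at least 1.6-fold lower number from compound 2 to compound 3 (0.22 log units; that floor lies within the scatter). Compound 3 is estimated at 6000 nM in this assay, with a range from 2000 nM to 20000 nM.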

Compound 3, half-maximal inhibitory concentration: 3100 nM
Compound 3: middle estimate off by 1.9-fold (0.29 log units), on the high side; measured number inside the range.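

In this assay, phenyl in place of methyl on an aromatic nitrogen now has a step that can be read, though only as a bound: an at least 3.2-fold lower number from compound 2 to compound 3 (0.50 log units; beyond the scatter). The value of compound 2 is a limit and not a number: the limit of > 10000 nM in this assay, at which 1 of the 3 values shown sits. With phenyl held on that nitrogen, methoxy in place of fluoro on an aromatic carbon gives a 1.3-fold lower number from compound 1 to compound 3 (0.12 log units; within the scatter), so this swap on the aromatic ring is not resolved in this assay.

The compounds shown leave open how other groups on that aromatic nitrogen would compare, such as an ethyl chain, a benzyl group or a pyridine ring, and so whether the step follows from the aromatic ring or from size alone. Also open, going by these compounds, is how an amine or a carboxylic acid on the entering phenyl would read.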